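A few compounds are considered here, and "the series" means these few. Any claim that something is new, unique, unknown or untested is made for them only; others in the source may bear on it.

In a functional assay on Jurkat cells (Homo sapiens) for inhibition, read by MTT assay, with a stated time of 72 h (a lower number here means a stronger inhibitor, a higher number a weaker inhibitor), compound 1 (`C=C(Br)C(=O)Nc1cccc(/C=C/C(=O)Nc2cccc(F)c2)c1`) gives 1000 nM and compound 2 (`C=C(Br)C(=O)Nc1cccc(/C=C/C(=O)Nc2ccc(C)cc2)c1`) gives 240 nM as the lower of the two numbers, which makes compound 2 the stronger inhibitor so far. Among the compounds with values here, the only measured step is a 4.2-fold lower number from compound 1 to compound 2 (0.62 log units; beyond the scatter) and came with 4-methylphenyl in place of 3-fluorophenyl on an amide-type nitrogen. Compound 3 (`C=C(Br)C(=O)Nc1cccc(/C=C/C(=O)Nc2ccc(OC(F)(F)F)cc2)c1`) carries trifluoromethoxy in place of methyl on an aromatic carbon, para to a large group (trifluoromethoxy in place of methyl on an aromatic carbon). Within the data shown here, the step of a 4.2-fold lower number from compound 1 to compound 2 (0.62 log units; beyond the scatter) involved other groups, so it shows only that such a swap can move the number modestly and gives no direction here. In this assay a step no larger than that is expected, most likely none beyond the scatter. On these data alone, the estimated step is a 1.3-fold higher number from compound 2 to compound 3 (0.10 log units; within the scatter) and the direction remains open. For compound 3 the estimated value is 300 nM with an expected range from 100 nM to 900 nM in this measurement.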

Compound 3, half-maximal inhibitory concentration: 30300 nM
Compound 3: middle estimate off by 100-fold (2.00 log units), on the low side; the measured number lies above the stated range.
By their numbers in this assay, from the lowest: compound 2; then compound 1; then compound 3.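

In this assay, the group on the aromatic carbon para to a large group turns out to matter far more than compound 2 suggested: trifluoromethoxy in place of methyl comes with a 130-fold higher number from compound 2 to compound 3 (2.10 log units; beyond the scatter), a large step toward a weaker inhibitor. Unlike the earlier step, this one shows that a single swap at this position can cost much of the activity, so this place does not accept every group equally. Nothing available here explains why the number rises so sharply.

With a single swap at this position, the compounds shown cannot separate the part played by the oxygen from that of the fluorines, or from the larger count of heavy atoms. Methoxy or trifluoromethyl at the same place would pull these apart.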